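A few compounds are considered here, and "the series" means these few. Any claim that something is new, unique, unknown or untested is made for them only; others in the source may bear on it.

Compound 1 `COc1cc(OC)c(-c2coc3cc(OCc4ccccc4C(F)(F)F)ccc3c2=O)cc1OC`: 4760 nM
Compound 2 `COc1cc(OC)c(-c2coc3cc(OCc4cccc(F)c4)ccc3c2=O)cc1OC`: 4920 nM
Compound 3 `COc1cc(OC)c(-c2coc3cc(OCc4ccc(Cl)cc4)ccc3c2=O)cc1OC`: 4450 nM

All three were tested in a functional assay on HCT-116 cells (Homo sapiens) for antiproliferative activity, read by MTT assay, with a stated time of 24 h; on this read-out higher numbers stand for weaker inhibition and lower numbers for stronger inhibition. They share a core and differ only in the substituted phenyl group on a saturated chain carbon bound to an oxygen on an aromatic ring. Compound 3 stands level with the other two, as a 1.1-fold lower number from compound 1 to compound 3 (0.03 log units; within the scatter) and a 1.1-fold lower number from compound 2 to compound 3 (0.04 log units; within the scatter) show.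

The next compound, compound 4 `COc1cc(OC)c(-c2coc3cc(OCc4cccc(Cl)c4)ccc3c2=O)cc1OC`, carries 3-chlorophenyl in place of 4-chlorophenyl on a saturated chain carbon bound to an oxygen on an aromatic ring. For the measured compounds named here, no measured step isolates this exact swap, so the evidence is indirect. Among these three compounds, changing the phenyl group has not yet moved the number beyond the scatter, and a 1.0-fold higher number from compound 1 to compound 2 (0.01 log units; within the scatter) is a further example. In this assay, a change beyond the scatter is therefore not expected here. The expected step is a 1.0-fold higher number from compound 3 to compound 4 (0.01 log units; within the scatter), which is estimated to stay within the scatter. For compound 4 the estimated value is 4600 nM, with an expected range of 2700 nM to 7800 nM.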

Compound 4, half-maximal inhibitory concentration: 1330 nM
Compound 4: middle estimate off by 3.5-fold (0.54 log units), on the high side; the measured number lies below the stated range.
By their numbers in this assay, from the lowest: compound 4; then compounds 3, 1 and 2 (each within the scatter of the next).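

In this assay this position proves more sensitive than the first three compounds suggested: 3-chlorophenyl in place of 4-chlorophenyl, with the same atoms joined differently, gives a change beyond the scatter (a 3.3-fold lower number from compound 3 to compound 4 (0.52 log units; beyond the scatter)). Compound 4 also stands apart from the other two compounds (a 3.7-fold lower number from compound 2 to compound 4 (0.57 log units; beyond the scatter); a 3.6-fold lower number from compound 1 to compound 4 (0.55 log units; beyond the scatter)), and the first of these steps is chloro in place of fluoro, so among these compounds both where the chlorine sits and which halogen is present can matter. Nothing available here explains why this arrangement gives the lower number.

Still open, as far as these compounds go, is whether 3-bromophenyl would go further in the same direction, or whether a 3-methoxyphenyl group or an amine on the phenyl ring would keep the lower number. A longer chain in place of the benzyl group could also show whether the effect depends on this exact linkage.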